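The source may hold more compounds than are shown below. What is called first, only, known or untested is meant among the compounds shown, and "the series" means these compounds.

Compound 3, `CC1CCN(C(=O)CCCNC(=O)c2ccc(S(C)(=O)=O)c([N+](=O)[O-])c2)CC1`, stands at a limit in an assay on isolated protein for inhibition of thyroid hormone receptor beta (Homo sapiens), read by fluorescence polarization (a higher number here means a weaker inhibitor, a lower number a stronger inhibitor), where it gives > 60000 nM, a limit rather than a number. Compound 1, `CN(Cc1cccc(F)c1)C(=O)CCCNC(=O)c1ccc(S(C)(=O)=O)c([N+](=O)[O-])c1`, likewise returns only the limit > 60000 nM in this assay. Compound 2, `CS(=O)(=O)c1ccc(C(=O)NCCC(=O)N2CCCc3ccccc32)cc1[N+](=O)[O-]`, also sits at the limit > 60000 nM in this assay. The one step among these, a step that the two limits leave unreadable from compound 1 to compound 3, cannot be read, and the whole of the evidence is the limit of > 60000 nM in this assay, at which 3 of the 3 values shown sit. Compound 4, `CS(=O)(=O)c1ccc(C(=O)NCCCC(=O)N2Cc3ccccc3C2)cc1[N+](=O)[O-]`, differs from compound 3 by a group of 9 heavy atoms (8 carbon, 1 nitrogen; one five-membered non-aromatic ring with 1 hetero atom, one six-membered aromatic ring of carbon only) in place of a group of 7 heavy atoms (6 carbon, 1 nitrogen; one six-membered non-aromatic ring with 1 hetero atom), on a carbonyl carbon. No readable measured step bears on this change, so nothing beyond the scatter is expected in this assay. The step that the limit leaves unreadable from compound 3 to compound 4 is thus estimated as essentially none. Compound 4 is expected to return 100000 nM, within 30000 nM to 300000 nM, most likely again as a limit.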

Compound 4, half-maximal inhibitory concentration: > 60000 nM
Compound 4 gave a limit, no number; the forecaster's own chance of this, stated with the estimate: 85%; the middle value lies beyond the limit too.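

Compound 4 returns only a limit, and neither its step from compound 3 nor its step from compound 1 can be read. The compounds shown leave open which change, if any, would give a measurable value in this assay: the limit of > 60000 nM in this assay, at which 4 of the 4 values shown sit.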